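The source may report more compounds than this note shows. Statements on the series, on what has been measured and on what is new or still open speak of the compounds shown alone.

Measured compounds:
- compound 1, `O=C(COc1ccc(Oc2ccccc2)cc1)Cn1ncc2cc(C(=O)O)ccc21` — 55 nM
- compound 2, `CCNC(=O)Nc1ccc2c(cnn2CC(=O)COc2ccc(Oc3ccccc3)cc2)c1` — 1600 nM
- compound 3, `O=C(COc1ccc(Oc2ccccc2)cc1)Cn1ncc2cc(NC(=O)NC3CCCCC3)ccc21` — 840 nM

All three share one core and are compared in an assay on microsomes from brain for inhibition of Fatty-acid amide hydrolase 1 (Rattus norvegicus), read by fluorescence and HPLC, with a stated time of 45 min; a higher number here means a weaker inhibitor, a lower number a stronger inhibitor. In this assay compound 1 gives 55 nM, the lowest number of the three; compound 3 gives 840 nM and compound 2 gives 1600 nM.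

The step that follows leads from compound 1 to compound 4, `CS(=O)(=O)NC(=O)c1ccc2c(cnn2CC(=O)COc2ccc(Oc3ccccc3)cc2)c1`, which has not yet been measured. The structural change is methanesulfonamido in place of hydroxy on a carbonyl carbon.

Among the compounds with values here, two measured steps bear on it. Both replace the carboxy group on the aromatic carbon with a urea: a 29-fold higher number from compound 1 to compound 2 (1.46 log units; beyond the scatter) and a 15-fold higher number from compound 1 to compound 3 (1.18 log units; beyond the scatter). Both were large losses. The change to compound 4 is different in kind: the carbonyl on the aromatic carbon stays, and only its hydroxy is exchanged for methanesulfonamido. Compound 4 is therefore expected to lose less than compounds 2 and 3 did, a change of a 2.2-fold higher number from compound 1 to compound 4 (0.34 log units; beyond the scatter) being estimated, which could be within the scatter. Compound 4 is estimated at 120 nM in this assay, within a range of 40 nM to 400 nM.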

Compound 4, half-maximal inhibitory concentration: 770 nM
Beside the measured number, compound 4's estimate is 6.4-fold (0.81 log units) below it; the whole stated range lies below it.
By their numbers in this assay, from the lowest: compound 1; then compounds 4, 3 and 2 (each within the scatter of the next, the first and the last beyond it).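

In this assay, keeping the carbonyl on the aromatic carbon proves not to be enough to keep compound 1's low number: exchanging only the hydroxy for methanesulfonamido gives a 14-fold higher number from compound 1 to compound 4 (1.15 log units; beyond the scatter) and this large step puts the carbonyl-retaining compound 4 in the same company as the ureas. Compound 4 cannot be told apart from the cyclohexyl urea, with a 1.1-fold lower number from compound 3 to compound 4 (0.04 log units; within the scatter) as the step between them, while the ethyl urea stands modestly apart, with a 2.1-fold lower number from compound 2 to compound 4 (0.32 log units; beyond the scatter) as the step; among these four compounds, then, each replacement of the carboxy group ends well above compound 1, whether or not the carbonyl on the aromatic carbon remains. Nothing measured here explains why this exchange on the carbonyl carbon carries so large a penalty.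

Still open, going by these compounds, is whether a smaller exchange on the same carbonyl carbon, such as a simple primary amide or a methyl ester, would stay closer to compound 1. Also open, on these data alone, is how a longer chain in place of the methyl on the sulfonyl, such as ethyl or butyl, would read in this assay.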